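The compounds below may be only part of what the source reports. "The series", "measured", "known", "first", "only" and "open" are said of these compounds alone.

Compound 1 (`COc1ccc2nc(NC(=O)CCCCC(=O)NO)sc2c1`) gives 23.9 ug/mL in a functional assay on ASPC1 cells (Homo sapiens) for cytotoxicity (a lower number here means a stronger inhibitor, a higher number a weaker inhibitor), and stands highest of the three measured numbers, which makes it the weakest of them. Compound 2 (`O=C(CCCCCCC(=O)Nc1nc2ccccc2s1)NO`) gives 5.69 ug/mL and compound 3 (`Cc1ccc2nc(NC(=O)CCCCCCC(=O)NO)sc2c1`) gives 0.54 ug/mL in this assay and both carry a longer chain than compound 1. The change to compound 4 (`O=C(CCCCC(=O)Nc1nc2ccc([N+](=O)[O-])cc2s1)NO`) is nitro in place of methoxy on an aromatic carbon and the chain of compound 1 stays as it is. Going by the values given here, only one measured step bears on this place: methyl in place of hydrogen on an aromatic carbon gave an 11-fold lower number from compound 2 to compound 3 (1.02 log units; beyond the scatter) as a large change. Among the compounds with values here, that is a different swap on a longer chain, and no measured compound carries nitro, so it shows that this place can matter but not how nitro will behave. The expected step is a 2.0-fold lower number from compound 1 to compound 4 (0.30 log units; within the scatter) and it is estimated as a modest lowering at most. For compound 4 the estimate is 12 ug/mL with an expected range from 3 ug/mL to 40 ug/mL as the likely span.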

Compound 4, half-maximal inhibitory concentration: > 30 ug/mL
Compound 4 was reported as a limit; the forecaster's own chance of this, stated with the estimate: 10%; at least 2.5-fold (0.39 log units) between middle value and limit.
By their numbers in this assay, from the lowest: compound 3; then compound 2; then compound 1. At a limit, above all of these: compound 4.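

In this assay compound 4 is reported only as a limit, not as a number: the limit of > 30 ug/mL in this assay, at which 1 of the 4 values shown sits. Nitro in place of methoxy on this aromatic carbon gives an at least 1.2-fold higher number from compound 1 to compound 4 (0.09 log units; that floor lies within the scatter) and that is only a floor, so the real gap may be larger, while the floor alone does not separate the two compounds. Going by these compounds alone, the result adds that this swap, on the shorter chain, brought no lowering of the number, whereas the only earlier step at this place was a different swap on the longer chain, an 11-fold lower number from compound 2 to compound 3 (1.02 log units; beyond the scatter) and a clear lowering.

Still open, from the compounds shown here alone, is how far beyond the limit compound 4 lies, and whether nitro would behave the same way on the longer chain of compound 2 and compound 3. Also open, going by these compounds, is what an amine or a carboxylic acid on this aromatic carbon would do.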